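The compounds below may be only part of what the source reports. "The series", "measured", "known", "first", "only" and "open" are said of these compounds alone.

Measured compounds:
compound 1, `Cc1nc(-c2ccccc2)c(C(=O)N2CCN(c3cccc(Cl)c3Cl)CC2)o1`, 133 nM
compound 2, `O=C(c1oc(C(F)(F)F)nc1-c1ccc(F)cc1)N1CCN(c2cccc(Cl)c2)CC1`, "not active" (no number reported)

Among the measured compounds shown here, in a functional assay on HL-60 cells (Homo sapiens) for inhibition, read by MTT assay, with a stated time of 72 h (on this read-out higher numbers stand for weaker inhibition and lower numbers for stronger inhibition), compound 1 gives 133 nM, and it is the only compound in this set with a numerical result. In this assay compound 2 is reported as "not active" (no number reported), without a number, and since it differs from compound 1 in several places the pair shows nothing more than one measured value beside one unmeasured one. Compound 3, `Cc1nc(-c2ccccc2)c(C(=O)N2CCN(c3cccc(F)c3)CC2)o1`, still awaits testing. It differs from compound 1 in a single place: 3-fluorophenyl in place of 2,3-dichlorophenyl on an amine nitrogen in a ring. For the measured compounds named here, no pair of measured compounds covers a swap of this kind, so the direction of the step is an open question. Compound 3 is expected to inhibit somewhat more weakly, a step of a 3.0-fold higher number from compound 1 to compound 3 (0.48 log units; beyond the scatter), which may still sit within the usual scatter. In this assay compound 3 is estimated at 400 nM, within a range of 120 nM to 2500 nM.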

Compound 3, half-maximal inhibitory concentration: 45 nM
Beside the measured number, compound 3's estimate is 8.9-fold (0.95 log units) above it; the measured number lies below the stated range.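

In this assay, replacing 2,3-dichlorophenyl with 3-fluorophenyl on the ring amine nitrogen gives a 3.0-fold lower number from compound 1 to compound 3 (0.47 log units; beyond the scatter) and therefore stronger inhibition. Among the compounds shown here, this is the first measured step at this position, and it shows that the group on this nitrogen can change the result with the rest of compound 1 held constant. It also shows that 2,3-dichlorophenyl is not required for inhibition here, although nothing shown explains the direction of the step.

Both chlorines leave and the fluorine enters in the same step, so the contribution of each change cannot be separated. Going by these compounds, how a plain phenyl or a pyridine ring would behave on this nitrogen also remains open.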